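Moving Methoxy Groups on a Dimethoxyphenyl Ring

The source may report more compounds than this note shows. Statements on the series, on what has been measured and on what is new or still open speak of the compounds shown alone.

Three measured compounds share one core and differ only in the group on the carbonyl carbon. In a functional assay on HCT-116 cells (Homo sapiens) for inhibition, read by MTT assay, with a stated time of 2 days, tested at 10 uM (a lower number here means less inhibition, a higher number more inhibition at the concentration tested (going by the name of the read-out)), compound 1 `COC(=O)c1cc(-n2cc(-c3cc(OC)cc(OC)c3)nn2)ccc1O` gives 3%. Compound 2 `COc1cc(OC)cc(-c2cn(-c3ccc(O)c(C(=O)OCCCc4ccccc4)c3)nn2)c1` gives 19%, and compound 3 `COc1cc(OC)cc(-c2cn(-c3ccc(O)c(C(=O)Nc4cccc(C(F)(F)F)c4)c3)nn2)c1` gives 62%. Among these three numbers compound 2 stands second highest: a number 16 percentage points higher from compound 1 to compound 2 (beyond the scatter), while a number 43 percentage points higher from compound 2 to compound 3 (beyond the scatter), and a number 59 percentage points higher from compound 1 to compound 3 (beyond the scatter).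

Compound 4 `COc1ccc(OC)c(-c2cn(-c3ccc(O)c(C(=O)OCCCc4ccccc4)c3)nn2)c1` keeps the 3-phenylpropoxy group of compound 2 and alters only the ring attached to the five-membered aromatic ring with 3 nitrogen: 2,5-dimethoxyphenyl in place of 3,5-dimethoxyphenyl on an aromatic carbon. Going by the values given here, every measured step changes the group on the carbonyl carbon, so none of them touches this part of the molecule, and no measured step bears on the change. With nothing in the measured data to push the number either way, the expectation is a step no larger than the scatter, no change at the digits printed from compound 2 to compound 4 (within the scatter). Compound 4 is therefore estimated at 19%, with a range from 5% to 40%.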

Compound 4, a percentage reported as inhibition, at one concentration (the size of the read-out at that concentration, not a potency): 13%
The estimate for compound 4 lay 6 percentage points above the measured number; measured number inside the range.
By their numbers in this assay, from the lowest: compounds 1, 4 and 2 (each within the scatter of the next, the first and the last beyond it); then compound 3.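

In this assay the swap of 3,5-dimethoxyphenyl for 2,5-dimethoxyphenyl gives a small result (a number 6 percentage points lower from compound 2 to compound 4 (within the scatter)). Going by these compounds alone, this is the first view of the group on the five-membered aromatic ring with 3 nitrogen, and it shows that, with the 3-phenylpropoxy group held fixed, these two arrangements of the same atoms cannot be told apart in this read-out at this single concentration. No measurement at hand offers an explanation for this result.

Still open, going by these compounds, is whether the same swap would also fall within the scatter with the (3-(trifluoromethyl)phenyl)amino group of compound 3 on the carbonyl carbon. Also open, on these data alone, is how a ring with a single methoxy group, or a hydroxy group in place of a methoxy group, would read at this position.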